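Changing the aryl group on the amide carbonyl

The source may hold more compounds than are shown below. What is called first, only, known or untested is meant among the compounds shown, and "the series" means these compounds.

Three compounds of the series carry a measured value in an assay on HEK293 cells for agonist activity at Bile acid receptor (Homo sapiens), read by a luciferase reporter; on this read-out lower numbers stand for an effect already at smaller amounts and higher numbers for an effect only at larger amounts of compound. Going by the values given here, compound 1 `CC(C)OC(=O)C1=CN(C(=O)c2cccs2)CC(C)(C)c2cc(C#N)[nH]c21` gives 16 nM, the lowest number of the three, and it differs from the others both in its core and in its aryl group, so no single step connects it to them. Compound 2 `CC(C)OC(=O)C1CN(C(=O)c2cccc(Cl)c2)CC(C)(C)c2cc(C#N)[nH]c21` gives 1300 nM. Among the compounds with values here, compound 3 `CC(C)OC(=O)C1CN(C(=O)c2ccc(C#N)cc2)CC(C)(C)c2cc(C#N)[nH]c21` gives 5700 nM, the highest number of the three; the step of a 4.4-fold higher number from compound 2 to compound 3 (0.64 log units; beyond the scatter) is the only one of a single change that bears on the aryl group on the carbonyl carbon.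

Compound 4 `CC(C)OC(=O)C1CN(C(=O)c2cccc(F)c2)CC(C)(C)c2cc(C#N)[nH]c21` has not yet been measured. It differs from compound 3 by 3-fluorophenyl in place of 4-cyanophenyl on a carbonyl carbon. Within the data shown here, the one relevant step shows that moving from 3-chlorophenyl to 4-cyanophenyl raised the number, so returning to a group that, like 3-chlorophenyl, bears a halogen at the 3-position is expected to bring the number back down toward that of compound 2. The expected step in this assay is therefore a 3.8-fold lower number from compound 3 to compound 4 (0.58 log units; beyond the scatter), a decrease beyond the scatter. For compound 4 the estimate is 1500 nM, with a range from 500 nM to 5000 nM.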

Compound 4, half-maximal effective concentration: 1300 nM
Beside the measured number, compound 4's estimate is 1.2-fold (0.06 log units) above it; the range from low to high includes it.
By their numbers in this assay, from the lowest: compound 1; then compounds 2 and 4 (each within the scatter of the next); then compound 3.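

In this assay, 3-fluorophenyl in place of 4-cyanophenyl on the carbonyl carbon gives a 4.4-fold lower number from compound 3 to compound 4 (0.64 log units; beyond the scatter), so the rise seen in a 4.4-fold higher number from compound 2 to compound 3 (0.64 log units; beyond the scatter) is not particular to the 3-chlorophenyl comparison and appears against a second halogen-bearing aryl group. Fluoro in place of chloro on an aromatic carbon gives no change at the digits printed from compound 2 to compound 4 (within the scatter), a first direct reading on the halogen itself, and this exchange leaves the number where it was within this pair. The data on hand offer no explanation for the gap between the 4-cyanophenyl compound and the two halogen-bearing compounds.

Both steps away from 4-cyanophenyl change the substituent and its place on the phenyl ring together, so the nitrile itself and its placement cannot be separated here. Going by these compounds, whether the insensitivity to the halogen extends to other small substituents on the phenyl ring, such as a methoxy group, a methyl group or an amine, also remains open, as does the effect of the same aryl changes on the core of compound 1.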